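Swapping isobutyl for phenoxy: a second look at acid dissociation

The source may hold more compounds than are shown below. What is called first, only, known or untested is meant among the compounds shown, and "the series" means these compounds.

Of the compounds shown here, three have been measured in a physicochemical assay for acid dissociation: compound 2 `COc1cccc(CNCCCNc2ccnc3cc(CC(C)C)ccc23)c1O`, compound 1 `COc1cccc(CNCCCNc2ccnc3cc(Oc4ccccc4)ccc23)c1O` and compound 3 `COc1ccc(F)cc1CNCCCNc1ccnc2cc(CC(C)C)ccc12`. Compound 2 gives 9.47, compound 1 gives 9.28 and compound 3 gives 9.47. Compound 1 differs from compound 2 by a single change, (phenoxy in place of isobutyl on an aromatic carbon), which made a step of a number 0.19 log units lower from compound 2 to compound 1 (within the scatter). Compound 3 differs from compound 2 in its core, (5-fluoro-2-methoxyphenyl in place of 2-hydroxy-3-methoxyphenyl on a saturated chain carbon bound to an amine nitrogen), with a step of no change at the digits printed from compound 2 to compound 3 (within the scatter).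

Compound 4 `COc1ccc(F)cc1CNCCCNc1ccnc2cc(Oc3ccccc3)ccc12` has not yet been measured in this assay. It stands to compound 3 as compound 1 stands to compound 2: the change is phenoxy in place of isobutyl on an aromatic carbon, and the surroundings of the place are described in the same words in both cases, so this is the same change made a second time. The expectation that the step from compound 3 to compound 4 will be of similar size, a number 0.19 log units lower from compound 3 to compound 4 (within the scatter), rests on the step of a number 0.19 log units lower from compound 2 to compound 1 (within the scatter) that the same change made once before. On that basis compound 4 is estimated at 9.28, with most repeat measurements expected to fall between 9 and 9.6.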

Compound 4, acid dissociation constant: 9.28
The estimate for compound 4 equals the measured number at the digits printed, and the stated range covers the measured number.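

In this assay, phenoxy in place of isobutyl on the core of compound 3 gives a step of a number 0.19 log units lower from compound 3 to compound 4 (within the scatter) and so matches the step of a number 0.19 log units lower from compound 2 to compound 1 (within the scatter) at the digits printed, which means the change carried from one core to the other without any visible difference in size. The step of no change at the digits printed from compound 1 to compound 4 (within the scatter) fits the same picture, but since every one of these steps lies within the usual scatter, this agreement between two cores does not show that the change has a real effect on this read-out, nor that it would carry to further cores. No measurement at hand bears on what lies behind these numbers.

The compounds shown leave open whether a larger step would appear with an amine, a carboxylic acid or a longer chain in place of isobutyl on that aromatic carbon. They also leave open whether such a step would repeat from one core to the other as closely as this one does.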